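This account rests on a few compounds, and the source may have more. Where it says the series, first, only, none or still open, it means among the compounds named here.

Of the compounds shown here, three have so far been tested in a functional assay on HeLa cells (Homo sapiens) for inhibition, read by CCK-8 assay, with a stated time of 72 h, tested at 2 uM; on this read-out lower numbers stand for less inhibition of growth and higher numbers for more inhibition of growth at the one concentration tested. Compound 1 `COc1ccc(SCc2ccc(/C=C/C(=O)Nc3ccccc3N)cc2)cc1OC` gives 10.1%, the lowest of the three numbers. Compound 2 `Nc1ccccc1NC(=O)c1ccc(CSc2cccc(F)c2)cc1` gives 22.5%, and compound 3 `Cc1cc(C)cc(SCc2ccc(C(=O)Nc3ccccc3N)cc2)c1` gives 40.2%; both stand above compound 1 by more than the scatter. For the measured compounds named here, the only pair that differs in one place is compound 2 and compound 3, where 3,5-dimethylphenyl in place of 3-fluorophenyl on the sulfur brings a rise of a number 17.7 percentage points higher from compound 2 to compound 3 (beyond the scatter), a modest and real change.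

Compound 4 `Nc1ccccc1NC(=O)/C=C/c1ccc(CSCCc2ccccc2)cc1` has not yet been measured. Compared with compound 1 it changes in one place: phenethyl in place of 3,4-dimethoxyphenyl on a sulfur. The 3,4-dimethoxyphenyl gives way to a phenethyl on the same sulfur, whose other neighbour is a saturated chain carbon.

Going by the values given here, the step from compound 2 to compound 3 is the only guide, since it too swaps the group on the sulfur, and it moved the read-out modestly upward. Nothing measured tells what removing the methoxy groups alone does. A small upward shift in this assay is therefore expected, of about a number 7.9 percentage points higher from compound 1 to compound 4 (within the scatter), possibly within the scatter. Compound 4 is estimated at 18%, within a range from 5% to 35%.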

Compound 4, percent growth inhibition at one concentration: 0.19%
For compound 4 the middle estimate is 17.8 percentage points above the measured one; measured number outside the range, below it.
By their numbers in this assay, from the lowest: compounds 4 and 1 (each within the scatter of the next); then compound 2; then compound 3.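

In this assay, replacing 3,4-dimethoxyphenyl with phenethyl on a sulfur gives a number 9.9 percentage points lower from compound 1 to compound 4 (within the scatter), so compound 1 and compound 4 cannot be told apart on this read-out, even though the group that enters has 0 hydrogen-bond acceptors and the group that leaves has 2. For the compounds shown here, the one earlier swap on a sulfur, made on a different core, gave a number 17.7 percentage points higher from compound 2 to compound 3 (beyond the scatter), so a change of group on a sulfur does not always move the number beyond the scatter; in this pair, a large change in the group leaves the two numbers together and low. No measurement on hand explains why this swap leaves the read-out within the scatter.

As far as these compounds go, it remains open whether a group of another kind on this sulfur, such as an amine, a carboxylic acid or a longer chain, would lift the number on the core of compound 1. From the compounds shown here alone, it also remains open whether phenethyl would behave the same way on the core of compound 3, where the read-out stands higher.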